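The source may report more compounds than this note shows. Statements on the series, on what has been measured and on what is new or still open speak of the compounds shown alone.

Compounds measured. In a functional assay on MCF7 cells (Homo sapiens) for cytotoxicity, read by MTT assay, with a stated time of 48 h (a lower number here means a stronger inhibitor, a higher number a weaker inhibitor), compound 1 `FC(F)=C(F)CCSc1ncc(-c2ccncc2)s1` gives only a limit, > 120000 nM. Compound 2 `FC(F)=C(F)CCSc1nc2ccccc2o1` also gives only a limit, > 120000 nM. Compound 3 `CC(c1nccs1)C(C#N)C#N` gives only a limit as well, > 120000 nM.

Compound 3 thus stands where all three measured compounds stand: at the limit of > 120000 nM in this assay, at which 3 of the 3 values shown sit, with no number of its own. Compound 4 `CC(C)(c1nccs1)C(C#N)C#N` differs from compound 3 by a single change, (methyl in place of hydrogen on a saturated chain carbon bound to an aromatic carbon and two saturated chain carbons). Within the data shown here, no step between two measured compounds is available, so the data give no reading of what such a change does. With every value shown being a limit, the step is expected to be none beyond the scatter. The step from compound 3 to compound 4 is estimated as a step that the limit leaves unreadable from compound 3 to compound 4. Compound 4 is expected to give 150000 nM in this assay, between 60000 nM and 400000 nM, most likely again as a limit rather than a number.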

Compound 4, half-maximal inhibitory concentration: > 120000 nM
Compound 4: a limit, no number; the forecaster's own chance of this, stated with the estimate: 85%; the middle value does not contradict the limit.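

No step can be read from compound 3 to compound 4, since both give only a limit: the limit of > 120000 nM in this assay, at which 4 of the 4 values shown sit. Going by these compounds, what the methyl in place of hydrogen does stays open, as does any actual number for these four compounds.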